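Chloro for methoxy on the aryl ring of compound 2

The source may report more compounds than this note shows. Statements on the series, on what has been measured and on what is new or still open speak of the compounds shown alone.

Of the compounds shown here, three sharing one core have been measured in a functional assay on HeLa cells (Homo sapiens) for antiproliferative activity, read by MTT assay, with a stated time of 96 h; a higher number here means a weaker inhibitor, a lower number a stronger inhibitor. Compound 2 `COc1ccc(N2C(=O)NC3(CSC4=C3C(=O)c3ncccc3C4=O)C2=O)cc1` stands lowest of the three, giving 1 nM. Compound 1 `CN(C)c1ccc(N2C(=O)NC3(CSC4=C3C(=O)c3ncccc3C4=O)C2=O)cc1` gives 10 nM, and the step of a 10-fold lower number from compound 1 to compound 2 (1.00 log units; beyond the scatter) shows that exchanging the group on the aryl ring moves the number well beyond the scatter. Compound 3 `O=C1NNC(=O)C2(CSC3=C2C(=O)c2ncccc2C3=O)N1`, which lacks the aryl ring altogether, gives 980 nM, the highest of the set.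

Compound 4 `O=C1C2=C(C(=O)c3ncccc31)C1(CS2)NC(=O)N(c2ccc(Cl)cc2)C1=O` differs from compound 2 in one place: chloro in place of methoxy on an aromatic carbon. Among the measured compounds shown here, no measured step covers chloro directly. For the measured compounds named here, the only step that bears on the change, from compound 1 to compound 2, concerns the same position and was modest in size, so a shift of comparable scale is plausible, though its direction cannot be read from the data. The estimated step of a 3.0-fold higher number from compound 2 to compound 4 (0.48 log units; beyond the scatter) is therefore taken as a small rise in the number. Compound 4 is expected to give about 3 nM in this assay, within a range from 0.5 nM to 20 nM.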

Compound 4, half-maximal inhibitory concentration: 2 nM
Beside the measured number, compound 4's estimate is 1.5-fold (0.18 log units) above it; low and high end bracket the measured number.
By their numbers in this assay, from the lowest: compounds 2 and 4 (each within the scatter of the next); then compound 1; then compound 3.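

In this assay, the exchange of 4-methoxyphenyl for 4-chlorophenyl leaves the number within the scatter, with a 2.0-fold higher number from compound 2 to compound 4 (0.30 log units; within the scatter), even though chloro counts no hydrogen-bond acceptor and methoxy counts one. The earlier compounds shown here showed only that this place responds to a change of group; the new step of a 5.0-fold lower number from compound 1 to compound 4 (0.70 log units; beyond the scatter) shows that compound 1 stands apart from a second group as well, so the gap from dimethylamino is not confined to methoxy. Nothing shown gives a cause for either step.

The compounds shown leave open how a carboxylic acid, a primary amine or a longer chain such as butoxy would behave on this aromatic carbon. They also leave open what plain hydrogen would give there, and whether chloro would be tolerated elsewhere on the ring.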